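Aryl variation on a shared core: working notes

The source may report more compounds than this note shows. Statements on the series, on what has been measured and on what is new or still open speak of the compounds shown alone.

Values in an ADME assay on Vero cells (Chlorocebus sabaeus) for cytotoxicity, read by neutral red uptake, tested at 49 ug/mL; on this read-out higher numbers stand for a weaker effect at the one concentration tested and lower numbers for a stronger effect:
compound 1 `O=C1CSC(c2ccc(O)cc2)N1CCN1CCCCC1`: 96%
compound 2 `COc1ccccc1C1SCC(=O)N1CCN1CCCCC1`: 100%
compound 3 `Cc1ccc(C2SCC(=O)N2CCN2CCCCC2)cc1`: 100%

Compound 3 stands level with compound 2 at the digits shown; compound 1 lies within the scatter of both, so the three measured numbers in this assay are not separated. For the measured compounds named here, the only single-place step among them is a number 4 percentage points higher from compound 1 to compound 3 (within the scatter), a swap on the aromatic ring that left the read-out where it was.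

Compound 4 `O=C1CSC(c2ccccc2Cl)N1CCN1CCCCC1` is not yet measured. Relative to compound 3 the change is 2-chlorophenyl in place of 4-methylphenyl on a saturated ring carbon. Going by the values given here, no measured pair swaps a methyl for a chlorine, and none moves the substituent on that aromatic ring, so the step to compound 4 has no direct precedent. Among the compounds with values here, the one step that bears on it, a number 4 percentage points higher from compound 1 to compound 3 (within the scatter), shows that exchanging the group on this ring did not shift this assay beyond the scatter, and compound 2, which carries its group at a different ring position, reads the same as compound 3.

On that basis the step of a number 2 percentage points lower from compound 3 to compound 4 (within the scatter) is expected to stay within the scatter. Compound 4 is estimated at 98% in this assay, with a range from 88% to 100%.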

Compound 4, a percentage reported as activity, at one concentration (the size of the read-out at that concentration, not a potency): 100%
Estimate against measurement, compound 4: 2 percentage points below; the range from low to high includes it.
By their numbers in this assay, from the lowest: compounds 1, 2, 3 and 4 (each within the scatter of the next).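

For the compounds shown here, the step to the 2-chlorophenyl group on the saturated ring carbon, no change at the digits printed from compound 3 to compound 4 (within the scatter) in this assay, adds a chloro-substituted aromatic ring to this position, a group the earlier compounds did not include. The two further comparisons, no change at the digits printed from compound 2 to compound 4 (within the scatter) with chloro in place of methoxy on an aromatic carbon, and a number 4 percentage points higher from compound 1 to compound 4 (within the scatter) with 2-chlorophenyl in place of 4-hydroxyphenyl, also stay within the scatter, so compound 4 is not separated from any earlier compound. All four aryl groups shown at this position therefore give readings that cannot be told apart in this assay, and no supporting measurement bears on why this is so.

The compounds shown leave open whether a carboxylic acid or a primary amine on the aromatic ring, or a longer chain at this position, would give a reading beyond the scatter. They also leave open how the read-out would respond to any change elsewhere on the shared core, since all four compounds differ only in the aryl group.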